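This account rests on a few compounds, and the source may have more. Where it says the series, first, only, none or still open, it means among the compounds named here.

Compound 1 `O=C(CCC(=O)OCCCCCCSc1ccc([N+](=O)[O-])c2nonc12)Nc1ccc(Br)cc1` gives 2160 nM in a functional assay on HOS cells (Homo sapiens) for inhibition, read by MTT assay, with a stated time of 72 h; on this read-out higher numbers stand for weaker inhibition and lower numbers for stronger inhibition. Of the two numbers shown it is the higher one, yet compound 2 `COc1ccc(NC(=O)CCC(=O)OCCCCCCSc2ccc([N+](=O)[O-])c3nonc23)cc1`, which gives 1800 nM, sits close: a 1.2-fold lower number from compound 1 to compound 2 (0.08 log units; within the scatter). Compound 3 `O=C(CCC(=O)N1CCCCC1)OCCCCCCSc1ccc([N+](=O)[O-])c2nonc12` differs from compound 1 by piperidin-1-yl in place of (4-bromophenyl)amino on a carbonyl carbon. For the measured compounds named here, the one measured step concerns a change on an aromatic carbon, not on the carbonyl carbon changed here, so no measured step bears directly on this change. Without a guide, a step within the scatter is expected, a 1.0-fold higher number from compound 1 to compound 3 (0.01 log units; within the scatter). Compound 3 is accordingly estimated at 2200 nM, with a range from 900 nM to 5500 nM.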

Compound 3, half-maximal inhibitory concentration: 1790 nM
For compound 3 the middle estimate is 1.2-fold (0.09 log units) above the measured one; the measured number falls inside the stated range.
By their numbers in this assay, from the lowest: compounds 3, 2 and 1 (each within the scatter of the next).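

In this assay, placing piperidin-1-yl on the carbonyl carbon gives a 1.2-fold lower number from compound 1 to compound 3 (0.08 log units; within the scatter), and the same group in place of (4-methoxyphenyl)amino gives a 1.0-fold lower number from compound 2 to compound 3 (0.00 log units; within the scatter). The three compounds therefore cannot be told apart here, even though this change replaces the aromatic ring with a non-aromatic one and removes a hydrogen-bond donor. No supporting measurement offers an explanation for this. Still open, from the compounds shown here alone, is whether a carboxylic acid or a simple dimethylamino group on this carbonyl carbon would also stay within the scatter.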